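The source may hold more compounds than are shown below. What is called first, only, known or untested is meant among the compounds shown, and "the series" means these compounds.

Compound 1 `O=C(CN1CCN(c2nnc(Cc3ccncc3)c3ccccc23)CC1)Nc1cccc(F)c1`: 6130 nM
Compound 2 `Cc1cccc(Cl)c1NC(=O)CN1CCN(c2nnc(Cc3ccccc3)c3ccccc23)CC1`: 53600 nM

Among the compounds with values here, in a functional assay on HT-29 cells (Homo sapiens) for cytotoxicity, read by MTT assay, with a stated time of 72 h (a lower number here means a stronger inhibitor, a higher number a weaker inhibitor), compound 1 gives 6130 nM, the lower of the two numbers measured so far. Compound 2 gives 53600 nM, and the gap between them lies beyond the usual scatter of repeated measurements. These two compounds differ in more than one place, so their gap does not show what any single change does.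

Compound 3 `O=C(CN1CCN(c2nnc(Cc3ccncc3)c3ccccc23)CC1)Nc1ccc(F)c(Cl)c1` keeps the core of compound 1 and changes only the ring at the end of the amide. It carries 3-chloro-4-fluorophenyl in place of 3-fluorophenyl on an amide-type nitrogen. Within the data shown here, no measured pair here isolates this kind of change, so the data offer no direct guide to its size. The starting point is compound 1 at 6130 nM. Among the measured compounds shown here, with one added chlorine as the only change, a small move towards a lower number in this assay is expected, probably not beyond the scatter. The estimated change is a 1.4-fold lower number from compound 1 to compound 3 (0.13 log units; within the scatter). The expected value for compound 3 is 4500 nM, with an estimated range from 1500 nM to 14000 nM.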

Compound 3, half-maximal inhibitory concentration: 880 nM
For compound 3 the middle estimate is 5.1-fold (0.71 log units) above the measured one; measured number below the stated range.
By their numbers in this assay, from the lowest: compound 3; then compound 1; then compound 2.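

Within the data shown here, with the core of compound 1 untouched, placing 3-chloro-4-fluorophenyl in place of 3-fluorophenyl on the amide-type nitrogen gives in this assay a 7.0-fold lower number from compound 1 to compound 3 (0.84 log units; beyond the scatter), the first comparison here that changes a single place and so the first that can be tied to one part of the molecule. It shows that the ring at the end of the amide is not a silent part of these structures: a swap that adds just one heavy atom, a chlorine, and gives the fluorine a different number in the group's name moves the cytotoxicity reading by more than repeated measurements would scatter. Nothing measured here explains the size of this step.

This single pair cannot tell whether the added chlorine, the changed place of the fluorine, or the two together produce the step, and a 3-chlorophenyl group on the same nitrogen would help to separate them. It also leaves open whether the same swap would act alike on the core of compound 2, and how a quite different end group, such as a methoxy-bearing ring or a carboxylic acid, would read.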